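The source may report more compounds than this note shows. Statements on the series, on what has been measured and on what is new or still open speak of the compounds shown alone.

The series rests on a shared core carrying two guanidine groups, and all three measured members were tested in an assay on isolated protein for inhibition of Trypsin (Homo sapiens), read by fluorescence, with a stated time of 15 min, tested at 50 uM; on this read-out lower numbers stand for less inhibition and higher numbers for more inhibition at the one concentration tested (going by the name of the read-out). Compound 1 `N=C(N)Nc1ccc(C(=O)Oc2cccc(NC(=N)N)c2)cc1` gives 100%, and compound 2 `N=C(N)Nc1ccc(C(=O)Nc2cccc(NC(=N)N)c2)cc1` gives 94.6%. Compound 3 `N=C(N)NCCCOC(=O)c1ccc(NC(=N)N)cc1` gives 78.9%, the lowest of the three numbers, and its gap to compound 2 and to compound 1 lies beyond the scatter in both cases. The account follows the step from compound 3 to compound 4 `N=C(N)NCCCCOC(=O)c1ccc(NC(=N)N)cc1`, which differs from compound 3 in one place: a group of 5 heavy atoms (2 carbon, 3 nitrogen; no ring) in place of a group of 4 heavy atoms (1 carbon, 3 nitrogen; no ring), on a saturated chain carbon, three bonds along the chain from an oxygen next to a carbonyl group. No step between two measured compounds matches this change, so there is nothing in the shown numbers to lean on for its size. With only one carbon added to a saturated chain and the rest of the molecule kept, the expected step in this assay is small, with no clear direction and likely within the scatter. On that basis, compound 4 is expected to give about 78% in this assay, with a range from 60% to 95%, which means an expected step of a number 0.9 percentage points lower from compound 3 to compound 4 (within the scatter).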

Compound 4, a percentage reported as inhibition, at one concentration (the size of the read-out at that concentration, not a potency): 84%
Compound 4: middle estimate off by 6 percentage points, on the low side; low and high end bracket the measured number.
By their numbers in this assay, from the lowest: compounds 3 and 4 (each within the scatter of the next); then compounds 2 and 1 (each within the scatter of the next).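

In this assay, the first step along this saturated chain, with the group of 5 heavy atoms in place of the group of 4 heavy atoms, gives a number 5.1 percentage points higher from compound 3 to compound 4 (within the scatter). Within the data shown here, this is the first reading at this position, and it shows that adding one chain carbon, with the rest of the molecule kept, leaves the number within the usual scatter of the read-out. No measured evidence accounts for the size of this step.

The compounds shown leave open whether a longer chain would also stay within the scatter, or whether an amine in place of the guanidine on the chain would keep the inhibition. With a single step at one concentration, they also leave open how potency changes along the chain.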